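The source may report more compounds than this note shows. Statements on the series, on what has been measured and on what is new or still open speak of the compounds shown alone.

For the measured compounds named here, compound 2, `COCOC/C1=C/C[C@](C)(CCC=C(C)C)/C=C/[C@@H](OC(=O)C=C(C)C)[C@](C)(O)/C=C/C1=O`, is the weaker of the two compounds measured so far in a functional assay on SW480 cells (Homo sapiens) for antiproliferative activity, read by MTT assay, with a stated time of 48 h; a higher number here means a weaker inhibitor, a lower number a stronger inhibitor: compound 2 gives 3710 nM, whereas compound 1, `CC(C)=CCC[C@]1(C)/C=C/[C@@H](OC(=O)C=C(C)C)[C@](C)(O)/C=C/C(=O)/C(CN2CCCC2)=C\C1`, gives 310 nM. Going by the values given here, the one step that connects them, a 12-fold higher number from compound 1 to compound 2 (1.08 log units; beyond the scatter), is large. Compound 3, `CC(C)=CCC[C@]1(C)/C=C/[C@@H](OC(=O)C=C(C)C)[C@](C)(O)/C=C/C(=O)/C(C(=O)N2CCCC2)=C\C1`, is not yet measured. It differs from compound 2 by (pyrrolidin-1-yl)carbonyl in place of (methoxymethoxy)methyl on a double-bonded ring carbon. Among the compounds with values here, the only step that bears on this change is the one from compound 1 to compound 2, and it goes the other way: there the pyrrolidin-1-yl group left and methoxymethoxy entered, with a large loss in potency. Compound 3 brings a pyrrolidine ring back, but bound through a carbonyl, so the earlier step is only a partial guide. The number for compound 3 is therefore expected to move back toward that of compound 1 by a 3.1-fold lower number from compound 2 to compound 3 (0.49 log units; beyond the scatter), and compound 3 is estimated at 1200 nM, with a range from 350 nM to 4000 nM.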

Compound 3, half-maximal inhibitory concentration: 15100 nM
Compound 3: the middle estimate sits 13-fold (1.10 log units) below what was measured; the whole stated range lies below it.
By their numbers in this assay, from the lowest: compound 1; then compound 2; then compound 3.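

In this assay, (pyrrolidin-1-yl)carbonyl in place of (methoxymethoxy)methyl gives a 4.1-fold higher number from compound 2 to compound 3 (0.61 log units; beyond the scatter), so the pyrrolidine ring on this double-bonded ring carbon does not by itself bring back the potency of compound 1. The change that alters only the link to that ring, (pyrrolidin-1-yl)carbonyl in place of (pyrrolidin-1-yl)methyl, gives a 49-fold higher number from compound 1 to compound 3 (1.69 log units; beyond the scatter), which shows that the carbon joining the ring to the core matters greatly at this position. No evidence on why the numbers move this way is available here.

The compounds shown leave open whether other amines on the same saturated chain carbon, such as a piperidine, a morpholine or a dimethylamino group, would match compound 1. They also leave open how a carboxylic acid or a primary amide would compare with compound 3 at this position.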